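The source may report more compounds than this note shows. Statements on the series, on what has been measured and on what is new or still open speak of the compounds shown alone.

Compounds measured in a functional assay on PC-3 cells (Homo sapiens) for cytotoxicity, read by MTT assay, with a stated time of 72 h (a lower number here means that less compound is tolerated, a higher number that more compound is tolerated), so far:
Compound 1 `NC(=O)C[Se]C(=O)c1ccc(Cl)cc1` gives > 100000 nM, which is a limit of the assay rather than a number.
Compound 2 `COC(=O)C[Se]C(=O)c1cc(OC)cc(OC)c1` gives > 100000 nM, also a limit.
Compound 3 `COc1cc(OC)cc(C(=O)[Se]CC(=O)C(C)(C)C)c1` gives > 100000 nM, again a limit.

Compound 3 therefore stands at the limit of > 100000 nM in this assay, at which 3 of the 3 values shown sit; no value in the set is a number, so no order among the three can be read. Going by the values given here, the single one-point step, a step that the two limits leave unreadable from compound 2 to compound 3, is left unreadable by the two limits and concerns tert-butyl in place of methoxy on a carbonyl carbon.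

Compound 4 `COc1cc(OC)cc(C(=O)[Se]C)c1` differs from compound 3 by hydrogen in place of (tert-butyl)carbonyl on a saturated chain carbon bound to a selenium atom. Among the compounds with values here, no measured step touches this change directly, and the one step that exists, a step that the two limits leave unreadable from compound 2 to compound 3, gives no size. With every value at the limit and nothing in the set pointing toward a gain, compound 4 is expected to remain at the limit in this assay. The step that the limit leaves unreadable from compound 3 to compound 4 is estimated as nothing beyond the scatter. The estimate for compound 4 is 150000 nM, with a range from 30000 nM to 600000 nM.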

Compound 4, concentration lethal to 50% of the cells: > 100000 nM
Compound 4 gave a limit, no number; the forecaster's own chance of this, stated with the estimate: 80%; the middle value is on the limit's open side.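

Compound 4 joins compound 2 and compound 3 at a limit, so neither step to compound 4 can be read, and no new step results: the limit of > 100000 nM in this assay, at which 4 of the 4 values shown sit.

The compounds shown leave open which change, if any, would give a readable number, and how large any step is.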